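Working notes on the step to compound 3

This account rests on a few compounds, and the source may have more. Where it says the series, first, only, none or still open, it means among the compounds named here.

Values in a physicochemical assay for solubility; on this read-out lower numbers stand for lower solubility and higher numbers for higher solubility:
compound 1 `CNC(=O)c1cc(C(=O)NC2CC2)cn(Cc2ccc(C)cc2)c1=O`: 24 ug/mL
compound 2 `CNC(=O)c1cc(C(=O)NC2CCOCC2)cn(Cc2ccccc2)c1=O`: >= 174 ug/mL

In this assay, for the measured compounds named here, compound 1 gives 24 ug/mL, the only true number so far. Compound 2 reads >= 174 ug/mL, which is a limit of the assay and not a number. Going by the values given here, compound 1 therefore sits under the one limit on hand, and no measured step connects the two compounds.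

Compound 3 `CNC(=O)c1cc(C(=O)NC2CC2)cn(CC2CCCCC2)c1=O` differs from compound 1 in one place: cyclohexyl in place of 4-methylphenyl on a saturated chain carbon bound to an aromatic nitrogen. In words, cyclohexyl stands in place of 4-methylphenyl on a saturated chain carbon bound to an aromatic nitrogen, so 4-methylbenzyl becomes cyclohexylmethyl.

Among the compounds with values here, no measured pair covers this change, so the expectation in this assay is only a small upward step, not clearly beyond the scatter. The expected step runs a 1.7-fold higher number from compound 1 to compound 3 (0.22 log units; within the scatter). The estimated value for compound 3 is 40 ug/mL, with an expected range of 14 ug/mL to 120 ug/mL.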

Compound 3, solubility: >= 148 ug/mL
Compound 3: a limit, no number; the forecaster's own chance of this, stated with the estimate: 10%; middle value at least 3.7-fold (0.56 log units) away from the limit.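

In this assay compound 3 gives >= 148 ug/mL, which is a limit of the assay and not a number. For the compounds shown here, the first measured step, with cyclohexyl in place of 4-methylphenyl on a saturated chain carbon bound to an aromatic nitrogen, is an at least 6.1-fold higher number from compound 1 to compound 3 (0.79 log units; beyond the scatter), so a change at this position alone can move the read-out beyond the scatter. The step gives only a lower bound on the size of the change, because compound 3 stands at a limit: the limit of >= 148 ug/mL in this assay, at which 1 of the 3 values shown sits.

Going by these compounds, how far compound 3 truly lies from compound 1 stays open. Also open, on these data alone, is whether the step carries over to other groups at this position, such as a longer chain like 2-cyclohexylethyl or a six-membered ring bearing an amine.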